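The source may report more compounds than this note shows. Statements on the series, on what has been measured and on what is new or still open speak of the compounds shown alone.

Compound 1 (`Cc1cccc(CN2CCc3ncn(COCc4ccccc4)c3/C(=C/c3ccccc3)C2=O)c1`) gives 34300 nM in a functional assay on HepG2 cells (Homo sapiens) for inhibition, read by MTT assay, with a stated time of 72 h (on this read-out lower numbers stand for stronger inhibition and higher numbers for weaker inhibition), and carries a 3-methylbenzyl group on the shared core. Compound 3 (`O=C1/C(=C\c2ccc(C(F)(F)F)cc2)c2c(ncn2COCc2ccccc2)CCN1Cc1ccccc1`) gives 51400 nM in this assay and so lies within the scatter of compound 1. Compound 2 (`O=C1/C(=C\c2ccncc2)c2c(ncn2COCc2ccccc2)CCN1Cc1ccccc1`) reads > 100000 nM as a limit of the assay and not a number. Going by the values given here, compound 1 thus stands level with compound 3, and these two hold the only true numbers so far. Among the compounds with values here, the one measured step (an at least 1.9-fold lower number from compound 2 to compound 3 (0.28 log units; that floor lies within the scatter)) puts 4-(trifluoromethyl)phenyl in place of pyridin-4-yl on a double-bonded chain carbon bound to a double-bonded ring carbon, which is not where the next change falls. Compound 4 (`O=C1/C(=C\c2ccccc2)c2c(ncn2COCc2ccccc2)CCN1Cc1ccc2ccccc2c1`) has naphthalen-2-yl in place of 3-methylphenyl on a saturated chain carbon bound to an amide-type nitrogen in a ring. Within the data shown here, since the only guide is compound 1 at 34300 nM and no measured step falls at that place, no step beyond the scatter is expected in this assay in either direction. The estimate for compound 4 is 30000 nM with an expected range from 12000 nM to 80000 nM in this measurement. The expected step is a 1.1-fold lower number from compound 1 to compound 4 (0.06 log units; within the scatter) by this estimate.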

Compound 4, half-maximal inhibitory concentration: 23700 nM
The estimate for compound 4 lay 1.3-fold (0.10 log units) above the measured number; the measured number falls inside the stated range.
By their numbers in this assay, from the lowest: compounds 4, 1 and 3 (each within the scatter of the next, the first and the last beyond it). At a limit, above all of these: compound 2.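

Putting naphthalen-2-yl in place of 3-methylphenyl on a saturated chain carbon bound to an amide-type nitrogen in a ring gives, in this assay, a 1.4-fold lower number from compound 1 to compound 4 (0.16 log units; within the scatter). Going by these compounds alone, this is the first reading at this place, and it shows that a group with 2 six-membered aromatic rings of carbon only can stand here, where one such ring stood, with no change beyond the scatter. Nothing given here bears on why the two groups read alike.

Going by these compounds, both groups at this place are aromatic and carbon-only, so it remains open whether an amine or a carboxylic acid on the aromatic group would move the number beyond the scatter. On these data alone, it also remains open whether a longer chain in place of the saturated chain carbon would do so.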